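Cytotoxicity notes: piperidine-carboxanilide series, compound 3 to 4

The compounds below may be only part of what the source reports. "The series", "measured", "known", "first", "only" and "open" are said of these compounds alone.

Measured so far in an ADME assay on PC-3 cells (Homo sapiens) for cytotoxicity, read by WST assay, tested at 100 uM; a higher number here means more inhibition at the concentration tested (going by the name of the read-out), a lower number less inhibition:
- compound 1, `CC(C)(C)CC(=O)Nc1cccc(C(=O)N2CCCC(C(=O)Nc3ccc(Cl)cc3)C2)c1`: 0%
- compound 2, `O=C(Nc1cccc(CN2CCCC2)c1)C1CCCN(C(=O)c2cc(C(F)(F)F)cc(C(F)(F)F)c2)C1`: 51%
- compound 3, `COC(=O)c1cccc(NC(=O)C2CCCN(C(=O)c3cc(C(F)(F)F)cc(C(F)(F)F)c3)C2)c1`: 0%

Compound 3 stands level with compound 1 at the digits given, and together they are the lowest of the three numbers in this assay. Among the compounds with values here, compound 2 is the one that stands apart, and the only step that can be read between two compounds differing in one place is the one from compound 2 to compound 3: a number 51 percentage points lower from compound 2 to compound 3 (beyond the scatter), for methoxycarbonyl in place of (pyrrolidin-1-yl)methyl on an aromatic carbon.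

Compound 4 is `Cn1cnnc1-c1cccc(NC(=O)C2CCCN(C(=O)c3cc(C(F)(F)F)cc(C(F)(F)F)c3)C2)c1`, not yet measured. Its change from compound 3 is 4-methyl-4H-1,2,4-triazol-3-yl in place of methoxycarbonyl on an aromatic carbon. Within the data shown here, no measured step involves this triazolyl group, so the step from compound 2 to compound 3 bears on it only by showing that the group at this position can move the read-out by a large amount; it does not show the direction for this new group. Compound 3 sits at the floor of the read-out, so a drop is not possible, and without a precedent for the entering group the expected step for compound 4 is small, a number 10 percentage points higher from compound 3 to compound 4 (within the scatter), with the range left open upwards. Compound 4 is therefore estimated at 10%, between 0% and 35%.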

Compound 4, a percentage reported as inhibition, at one concentration (the size of the read-out at that concentration, not a potency): 0%
For compound 4 the middle estimate is 10 percentage points above the measured one; measured number inside the range.
By their numbers in this assay, from the lowest: compounds 1, 3 and 4 (each within the scatter of the next); then compound 2.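

In this assay, 4-methyl-4H-1,2,4-triazol-3-yl in place of methoxycarbonyl gives no change at the digits printed from compound 3 to compound 4 (within the scatter), so a group with a five-membered aromatic ring on this aromatic carbon reads the same as methoxycarbonyl, at the floor of the read-out. The large step seen earlier now has a second case, a number 51 percentage points lower from compound 2 to compound 4 (beyond the scatter), so among compounds 2, 3 and 4 the read-out appears only with (pyrrolidin-1-yl)methyl at this position, and its loss is not tied to methoxycarbonyl alone. No measurement to hand bears on what lies behind this.

As far as these compounds go, with compound 3 and compound 4 both at the floor, the read-out cannot separate the two groups, and how far either lies below any threshold for a response stays unknown. From the compounds shown here alone, it also remains open whether the response of compound 2 follows the amine itself, as a dimethylaminomethyl, piperidin-1-ylmethyl or plain aminomethyl group at this place would test, or whether a carboxylic acid or a longer chain ending in pyrrolidine would shift it.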